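The source may report more compounds than this note shows. Statements on the series, on what has been measured and on what is new or still open speak of the compounds shown alone.

Values so far (a functional assay on MCF7 cells (Homo sapiens) for inhibition, read by MTT assay, with a stated time of 72 h; a higher number here means a weaker inhibitor, a lower number a stronger inhibitor):
- Compound 1 `Cc1ccc(-c2nnc(SCCCN3CCN(c4nc5ccccc5s4)CC3)o2)cc1` gives 107000 nM
- Compound 2 `Brc1ccc(-c2nnc(SCCCN3CCN(c4nc5ccccc5s4)CC3)o2)cc1` gives 96300 nM
- Compound 3 `c1ccc(-c2nnc(SCCCN3CCN(c4nc5ccccc5s4)CC3)o2)cc1` gives 76900 nM

Compound 3 cannot be told apart from the other two (a 1.4-fold lower number from compound 1 to compound 3 (0.14 log units; within the scatter)) and (a 1.3-fold lower number from compound 2 to compound 3 (0.10 log units; within the scatter)). Compound 4 `O=C(NCc1nnc(SCCCN2CCN(c3nc4ccccc4s3)CC2)o1)c1ccccc1` carries benzamidomethyl in place of phenyl on an aromatic carbon. The measured steps only swap a small substituent on the phenyl, as in bromo in place of methyl (a 1.1-fold lower number from compound 1 to compound 2 (0.05 log units; within the scatter)), and all stay within the scatter. None replaces the phenyl itself, so they guide this larger change only weakly. In this assay no step beyond the scatter is therefore expected, in either direction. The estimated step is small (a 1.1-fold lower number from compound 3 to compound 4 (0.04 log units; within the scatter)). Compound 4 is estimated at 70000 nM (expected range 25000 nM to 160000 nM).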

Compound 4, half-maximal inhibitory concentration: 39000 nM
For compound 4 the middle estimate is 1.8-fold (0.25 log units) above the measured one; measured number inside the range.
By their numbers in this assay, from the lowest: compounds 4, 3, 2 and 1 (each within the scatter of the next, the first and the last beyond it).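

In this assay, benzamidomethyl replaces the whole phenyl rather than a small substituent on it, and the result against the unsubstituted parent is a 2.0-fold lower number from compound 3 to compound 4 (0.29 log units; within the scatter). Against the substituted phenyls, the steps modestly pass the scatter: a 2.5-fold lower number from compound 2 to compound 4 (0.39 log units; beyond the scatter) and a 2.7-fold lower number from compound 1 to compound 4 (0.44 log units; beyond the scatter). Nothing measured here bears on what lies behind these steps. From the compounds shown here alone, it remains open whether the amide hydrogen, the carbonyl or the larger size of benzamidomethyl matters most. Also open, going by these compounds, is how an amine or a carboxylic acid in place of benzamidomethyl would compare.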